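The source may hold more compounds than are shown below. What is called first, only, known or untested is meant among the compounds shown, and "the series" means these compounds.

Measured so far:
In a functional assay on a cell-free system (plasma) with sterol O-acyltransferase, Soat (Rattus norvegicus) as the target (a higher number here means that more compound is needed for the effect, a lower number that less compound is needed), compound 1 `CSc1cc(C)nc(SC)c1NC(=O)N(Cc1cccc(-c2cnn(C)c2)c1)C1CCCCCC1` gives > 0.1 mg/kg, which is a limit of the assay and not a number.
In this assay compound 2 `CSc1cc(C)nc(SC)c1NC(=O)N(Cc1ccccc1)Cc1cccc(-c2cnn(C)c2)c1` gives > 0.1 mg/kg, again a limit.
In this assay compound 3 `CSc1cc(C)nc(SC)c1NC(=O)N(Cc1ccc(-c2cnn(C)c2)cc1)C1CCCCCC1` gives > 0.1 mg/kg, also a limit.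

Compound 1 and compound 2 differ in one place: benzyl in place of cycloheptyl on an amide-type nitrogen. Because both values sit at the limit of > 0.1 mg/kg in this assay, at which 3 of the 3 values shown sit, the step that the two limits leave unreadable from compound 1 to compound 2 has no readable size. Compound 3 is built from the same atoms as compound 1, joined differently; the difference between the two cores is not broken down here.

Compound 4 `CSc1cc(C)nc(SC)c1NC(=O)N(Cc1ccccc1)Cc1ccc(-c2cnn(C)c2)cc1` has not yet been measured. It stands to compound 3 exactly as compound 2 stands to compound 1: benzyl in place of cycloheptyl on an amide-type nitrogen. The surroundings of the changed nitrogen are the same word for word, so this is the same change.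

With every measured value at a limit, there is no number to carry over. The step from compound 3 to compound 4 is therefore expected to be close to nothing, a step that the limit leaves unreadable from compound 3 to compound 4, and this rests only on the unreadable earlier step that the two limits leave unreadable from compound 1 to compound 2. Compound 4 is expected to give about 0.3 mg/kg, between 0.1 mg/kg and 3 mg/kg, most likely reported once more as a limit.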

Compound 4, dose for half-maximal effect: > 0.1 mg/kg
Compound 4 ended at the assay's limit; the forecaster's own chance of this, stated with the estimate: 85%; the middle value lies beyond the limit too.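

Compound 3 and compound 4 both sit at a limit of the assay and not at a number, so no size can be read for the step between them: the limit of > 0.1 mg/kg in this assay, at which 4 of the 4 values shown sit.

The compounds shown leave open how much compound any of them needs for the effect in this assay, and whether benzyl or cycloheptyl on the amide-type nitrogen makes any difference there.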